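Without its hydroxy group, compound 4 should stay weak

The source may report more compounds than this note shows. Statements on the series, on what has been measured and on what is new or still open speak of the compounds shown alone.

Compound 1 `O=C(Nc1ccc(O)cc1)c1ncc(-c2ccccc2)o1`: 1080 nM
Compound 2 `O=C(Nc1cccc(O)c1)c1ncc(-c2ccccc2)o1`: > 30000 nM (a limit)
Compound 3 `COc1ccc(NC(=O)c2ncc(-c3ccccc3)o2)cc1`: > 30000 nM (a limit)

In a functional assay on A549 cells (Homo sapiens) for cytotoxicity, read by CCK-8 assay (a higher number here means a weaker inhibitor, a lower number a stronger inhibitor), compound 3 gives > 30000 nM and this is a limit, not a number. From the compounds shown here alone, that puts compound 3 at the limit of > 30000 nM in this assay, at which 2 of the 3 values shown sit, and its true value remains unknown. Compound 4 `Cc1ccc(NC(=O)c2ncc(-c3ccccc3)o2)cc1` differs from compound 3 by carrying methyl in place of methoxy on an aromatic carbon, para to a large group (methyl in place of methoxy on an aromatic carbon). Within the data shown here, two measured steps bear on this change. Shifting the hydroxy group gave an at least 27-fold higher number from compound 1 to compound 2 (1.44 log units; beyond the scatter) and adding methyl to its oxygen gave an at least 27-fold higher number from compound 1 to compound 3 (1.44 log units; beyond the scatter) as the second large loss of strength. Among these compounds, only compound 1 gives a measured number, and compound 4, like compound 3, has no hydroxy group. No step beyond the scatter is therefore expected in this assay and the expected step is an at least 1.2-fold lower number from compound 3 to compound 4 (0.07 log units; that floor lies within the scatter) in size. For compound 4 the estimate is 25000 nM with an expected range from 7000 nM to 30000 nM as its two ends, and a report as a limit alone is quite likely.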

Compound 4, half-maximal inhibitory concentration: > 30000 nM
Compound 4: a limit, no number; the forecaster's own chance of this, stated with the estimate: 70%; middle value at least 1.2-fold (0.07 log units) from the limit.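

Putting methyl in place of hydroxy on this aromatic carbon gives an at least 27-fold higher number from compound 1 to compound 4 (1.44 log units; beyond the scatter), so a replacement with no oxygen at all costs at least as much as capping the hydroxy group or shifting it. The steps to compound 4 from compound 2 and from compound 3 cannot be read, as both ends of each are limits, so methyl and methoxy here cannot be told apart in this assay. Of the four compounds, only compound 1 keeps a measured number, and the others share one limit: the limit of > 30000 nM in this assay, at which 3 of the 4 values shown sit.

From the compounds shown here alone, how much of the strength of compound 1 depends on the hydroxy group itself stays open, and an amine or a carboxylic acid at this position would test that. Going by these compounds, the true values of compound 2, compound 3 and compound 4 also remain unknown.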